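The source may report more compounds than this note shows. Statements on the series, on what has been measured and on what is new or still open speak of the compounds shown alone.

Four compounds share one design: a hydroxamic acid carried on a chain that is attached to an aromatic ring, and on the same ring a second chain ending in a ketone that bears a further aromatic ring. Compound 1 is `O=C(/C=C/c1cccc(/C=C/C(=O)c2ccccc2)c1)NO`, compound 2 is `CN1CCN(c2cccc(C(=O)/C=C/c3cccc(/C=C/C(=O)NO)c3)c2)CC1`, compound 3 is `CN1CCN(c2ccccc2C(=O)/C=C/c2ccc(/C=C/C(=O)NO)nc2)CC1`, and compound 4, not yet measured, is `O=C(/C=C/c1ccc(/C=C/C(=O)c2ccccc2)cn1)NO`. All are tested in a functional assay on K562 cells (Homo sapiens) for antiproliferative activity, read by MTT assay, with a stated time of 72 h; a lower number here means a stronger inhibitor, a higher number a weaker inhibitor. In this assay compound 1 gives 3210 nM, compound 2 gives 990 nM, and compound 3 gives 1220 nM. Compound 3 and compound 2 lie within the scatter of each other; the difference between the two cores is not broken down here.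

One structural change is seen twice. From compound 2 to compound 1 it is hydrogen in place of 4-methylpiperazin-1-yl on an aromatic carbon, and it made the step of a 3.2-fold higher number from compound 2 to compound 1 (0.51 log units; beyond the scatter). From compound 3 to compound 4 it is hydrogen in place of 4-methylpiperazin-1-yl on an aromatic carbon. The place differs in one respect: in the first pair the change sits meta to a large group, in the second ortho to a large group, so this is the same kind of change rather than the same change. Because compound 1 gives 3210 nM after the group is removed from compound 2, a step of similar size is expected here, and the expected step is a 2.9-fold higher number from compound 3 to compound 4 (0.46 log units; beyond the scatter). Compound 4 is therefore estimated at 3500 nM, with a range of 1500 nM to 8000 nM.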

Compound 4, half-maximal inhibitory concentration: 690 nM
Compound 4: middle estimate off by 5.1-fold (0.71 log units), on the high side; the whole stated range lies above it.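

Replacing 4-methylpiperazin-1-yl with hydrogen gives a 1.8-fold lower number from compound 3 to compound 4 (0.25 log units; within the scatter) in this assay, so on this core the group's removal has no effect that can be told from the scatter of the measurement. The same structural change therefore cannot be treated as a fixed step that carries over from one core to the other in this series, and the result of one pair would have been a poor guide to the other: the same change on two cores in this assay, a 3.2-fold higher number (0.51 log units; beyond the scatter) from compound 2 to compound 1 and a 1.8-fold lower number (0.25 log units; within the scatter) from compound 3 to compound 4, 5.7-fold (0.76 log units) apart, beyond the scatter of two such steps This does not show why the two steps differ, as the pairs differ both in the core and in where the group sits on the ring, and a single pair on each core cannot separate those two differences.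

As far as these compounds go, it remains open whether the gap between the steps follows the core or the place of the group, a question that could be tested by putting 4-methylpiperazin-1-yl in one fixed place on both cores. From the compounds shown here alone, it is also open whether another amine, such as morpholine or dimethylamino, or a carboxylic acid in that place would behave like 4-methylpiperazin-1-yl on either core.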